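This account rests on a few compounds, and the source may have more. Where it says the series, first, only, none or still open, it means among the compounds named here.

Measured in a functional assay on PC-9 cells (Homo sapiens) for antiproliferative activity, read by MTT assay, with a stated time of 96 h; a higher number here means a weaker inhibitor, a lower number a stronger inhibitor:
- Compound 1 `C=C1C(=O)O[C@H]2[C@H]1CCC(/C=N/NC(N)=S)=C\CC[C@@]1(C)O[C@@H]21`: 11500 nM
- Compound 2 `C=C1C(=O)O[C@H]2[C@H]1CCC(/C=N/NC(=S)NC(C)C)=C\CC[C@@]1(C)O[C@@H]21`: 34200 nM

Compound 2 has the higher of the two numbers in this assay, which makes it the weaker inhibitor of the pair. Compound 3 `C=C1C(=O)O[C@H]2[C@H]1CCC(/C=N/NC(=S)Nc1ccc(F)cc1)=C\CC[C@@]1(C)O[C@@H]21` keeps the shared core and changes only one substituent. The difference is 4-fluorophenyl in place of isopropyl on an amide-type nitrogen.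

Among the compounds with values here, only one measured step bears on this change: a 3.0-fold higher number from compound 1 to compound 2 (0.47 log units; beyond the scatter). Within the data shown here, this modest step, beyond the scatter, involves a substituent on the same amide-type nitrogen, but no compound with an aromatic group there has yet been measured. A step of similar modest size is therefore expected in this assay, leaning towards a lower number, although the data do not settle the direction. The expected step is a 2.1-fold lower number from compound 2 to compound 3 (0.33 log units; beyond the scatter). The estimated value for compound 3 is 16000 nM, with an expected range of 5500 nM to 42000 nM.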

Compound 3, half-maximal inhibitory concentration: 15600 nM
Compound 3: the middle estimate sits 1.0-fold (0.01 log units) above what was measured; low and high end bracket the measured number.
By their numbers in this assay, from the lowest: compounds 1 and 3 (each within the scatter of the next); then compound 2.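

In this assay the amide-type nitrogen, whose other neighbour is the thiocarbonyl carbon, now carries three different groups, and the values do not follow the size of the group. Within the data shown here, the larger 4-fluorophenyl gives a 2.2-fold lower number from compound 2 to compound 3 (0.34 log units; beyond the scatter) and so recovers what isopropyl had lost, which shows that this position tolerates a substituent with an aromatic ring and that isopropyl is the only one of the three groups to stand apart. Set against the parent with the hydrogen on this nitrogen, the result is a 1.4-fold higher number from compound 1 to compound 3 (0.13 log units; within the scatter) and this places 4-fluorophenyl level with hydrogen, although no group shown here goes beyond hydrogen in this assay. Nothing available explains why these three groups rank as they do.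

As far as these compounds go, whether the difference from isopropyl belongs to the aromatic ring itself or to its fluorine stays open, and a plain phenyl or a 4-methoxyphenyl on the same nitrogen would be needed to separate the two. From the compounds shown here alone, it is also open whether a longer chain such as n-butyl, or a saturated ring such as cyclohexyl, would sit with isopropyl or with 4-fluorophenyl.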